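Methoxy for chloro on the aryl ring of a thiourea series

This account rests on a few compounds, and the source may have more. Where it says the series, first, only, none or still open, it means among the compounds named here.

Three measured compounds share a core and differ in the aryl groups. In a functional assay on PC-3 cells (Homo sapiens) for cytotoxicity, read by sulforhodamine B assay, with a stated time of 48 h (on this read-out lower numbers stand for stronger inhibition of growth and higher numbers for weaker inhibition of growth), compound 1 `CC1=C(C(=O)Nc2ccc(F)c(Cl)c2)C(c2cccc(Cl)c2)NC(=S)N1` gives 25100 nM; compound 2 `CC1=C(C(=O)Nc2ccc(Cl)c(Cl)c2)C(c2cccc(Oc3ccccc3)c2)NC(=S)N1` gives 9770 nM; compound 3 `CC1=C(C(=O)Nc2ccc(Cl)c(Cl)c2)C(c2ccccc2O)NC(=O)N1` gives 33900 nM. Compound 1 stands second highest of the three numbers: compound 3 lies within the scatter of it, while compound 2 lies beyond the scatter with the lower number. Compound 4 `COc1cccc(C2NC(=S)NC(C)=C2C(=O)Nc2ccc(F)c(Cl)c2)c1` is not yet measured in this assay. It differs from compound 1 by methoxy in place of chloro on an aromatic carbon. Among the measured compounds shown here, no measured pair shows this change, so the step from compound 1 to compound 4 is expected to stay roughly within the scatter, with no clear direction; the estimate is a 1.2-fold higher number from compound 1 to compound 4 (0.08 log units; within the scatter). Compound 4 is expected at 30000 nM, ranging from 12000 nM to 75000 nM.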

Compound 4, concentration for 50% growth inhibition: 23400 nM
Compound 4: the middle estimate sits 1.3-fold (0.11 log units) above what was measured; the measured number falls inside the stated range.
By their numbers in this assay, from the lowest: compound 2; then compounds 4, 1 and 3 (each within the scatter of the next).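

In this assay, among the compounds shown here, the change from 3-chlorophenyl to 3-methoxyphenyl gives a 1.1-fold lower number from compound 1 to compound 4 (0.03 log units; within the scatter), the only step so far between compounds that differ in one place. At this position, meta to a large group, methoxy can therefore stand in for chloro with no readable change in growth inhibition, even with one more hydrogen-bond acceptor. No measured property is available to explain this result. Still open, going by these compounds, is whether an amine or a carboxylic acid at this position would also leave the number unchanged. Also open, on these data alone, is whether methoxy for chloro reads the same with other aryl amide groups.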